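Methyl in place of hydrogen on a triazene nitrogen

The source may hold more compounds than are shown below. What is called first, only, known or untested is meant among the compounds shown, and "the series" means these compounds.

Compound 1 `CN/N=N/c1nc[nH]c1C(=O)OC` is one of two measured compounds in a functional assay on L1210 cells (Mus musculus) for antiproliferative activity (on this read-out higher numbers stand for higher potency (the scale is a negative logarithm) and lower numbers for lower potency), where compound 1 gives 3.35. Compound 2 `CN/N=N/c1nc[nH]c1C(=O)N1CCCC1` differs at the carbonyl carbon, with pyrrolidin-1-yl in place of methoxy, and in this assay compound 2 gives 3.28; the step of a number 0.07 log units lower from compound 1 to compound 2 (within the scatter) lies within the scatter. On the numbers shown, compound 1 stands highest of the two, yet its nearest neighbour sits within the scatter, so no order between them can be claimed.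

Compound 3 `COC(=O)c1[nH]cnc1/N=N/N(C)C` differs from compound 1 in a single place: methyl in place of hydrogen on an amine nitrogen. Going by the values given here, no measured step touches this position; the one step at hand changed the carbonyl end and stayed within the scatter. A step no larger than the scatter is therefore expected, with no direction favoured, and compound 3 is estimated at 3.4, in the range 2.9 to 3.9. This estimate means an expected step of a number 0.05 log units higher from compound 1 to compound 3 (within the scatter).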

Compound 3, logarithm of the reciprocal of the active concentration, log(1/C): 3.86
For compound 3 the middle estimate is 0.46 log units below the measured one; measured number inside the range.
By their numbers in this assay, from the lowest: compounds 2 and 1 (each within the scatter of the next); then compound 3.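

In this assay, going by these compounds alone, the change from methylamino to dimethylamino gives a number 0.51 log units higher from compound 1 to compound 3 (beyond the scatter) and is the only step so far that lies beyond the scatter. The earlier change at the carbonyl carbon gave a number 0.07 log units lower from compound 1 to compound 2 (within the scatter) and stayed within it, so the amine nitrogen is the one place among these compounds where a single change has moved the number. No information is available that accounts for this step.

The compounds shown do not tell whether a longer chain such as ethyl on this nitrogen would go further or reverse the step. They also leave open whether methyl in place of hydrogen gives a similar step when pyrrolidin-1-yl or a carboxylic acid stands at the carbonyl end.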